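Swapping the Sulfonyl Aromatic Group: Expected Plasma Stability

This account rests on a few compounds, and the source may have more. Where it says the series, first, only, none or still open, it means among the compounds named here.

Of the compounds shown here, three sharing one core have been measured in an ADME assay on a cell-free system (plasma, Homo sapiens) for metabolic stability, read by LC-MS, using NADPH, with a stated time of 60 min, tested at 1 uM; on this read-out lower numbers stand for a less stable compound and higher numbers for a more stable compound. Compound 1 `COc1ccc(S(=O)(=O)N2CCCC[C@H]2C(=O)O[C@@H](Cc2c(Cl)c[n+]([O-])cc2Cl)c2ccc(OC(F)F)c(OCC3CC3)c2)cc1C(=O)N(C)C` gives 88.2%, compound 2 `CN(C)C(=O)c1cccc(S(=O)(=O)N2CCCC[C@H]2C(=O)O[C@@H](Cc2c(Cl)c[n+]([O-])cc2Cl)c2ccc(OC(F)F)c(OCC3CC3)c2)c1` gives 105%, and compound 3 `CNC(=O)c1cc(S(=O)(=O)N2CCS[C@H]2C(=O)O[C@@H](Cc2c(Cl)c[n+]([O-])cc2Cl)c2ccc(OC(F)F)c(OCC3CC3)c2)cn1C` gives 100%. Compound 3 stands apart from compound 1 by a gap beyond the usual scatter, while its distance to compound 2 lies within that scatter, so compounds 2 and 3 cannot be told apart on this read-out.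

Compound 4 `Cn1cnc(S(=O)(=O)N2CCS[C@H]2C(=O)O[C@@H](Cc2c(Cl)c[n+]([O-])cc2Cl)c2ccc(OC(F)F)c(OCC3CC3)c2)c1` differs from compound 3 in a single place: a group of 6 heavy atoms (4 carbon, 2 nitrogen; one five-membered aromatic ring with 2 hetero atoms) in place of a group of 10 heavy atoms (7 carbon, 2 nitrogen, 1 oxygen; one five-membered aromatic ring with 1 hetero atom), on a sulfonyl sulfur. Going by the values given here, the only measured step, a number 16.8 percentage points higher from compound 1 to compound 2 (beyond the scatter), concerns a change on the aromatic group attached to the sulfonyl sulfur as well, and it was modest. Among the compounds with values here, no measured pair tests the exchange of one whole aromatic group for another at that position, so the present change is weakly informed. Given that all three measured compounds already sit high, and that the one related step was small, the step from compound 3 to compound 4 is expected to be a number 2 percentage points lower from compound 3 to compound 4 (within the scatter), within the scatter. Compound 4 is therefore estimated to give 98% in this assay, in a range from 82% to 110%.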

Compound 4, percent of the compound remaining: 101%
Compound 4: the middle estimate sits 3 percentage points below what was measured, and the stated range covers the measured number.
By their numbers in this assay, from the lowest: compound 1; then compounds 3, 4 and 2 (each within the scatter of the next).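

Exchanging the whole aromatic group on the sulfonyl sulfur for 1-methyl-1H-imidazol-4-yl gives, in this assay, a number 1 percentage points higher from compound 3 to compound 4 (within the scatter). Going by these compounds alone, this is the first measured exchange of one entire aromatic group for another at this position, and the read-out does not separate the two groups. The group that enters has 6 heavy atoms and 0 hydrogen-bond donors, against 10 heavy atoms and 1 hydrogen-bond donor in the group that leaves, yet the step stays within the scatter, and no measured evidence accounts for this result.

Going by these compounds, it remains open whether 1-methyl-1H-imidazol-4-yl would give a similar number on the core of compound 1. Also open, on these data alone, is how this position would respond to a group without an aromatic ring, such as a butyl chain, or to an aromatic group carrying an amine or a carboxylic acid.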